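The compounds below may be only part of what the source reports. "The series", "measured", "known", "first", "only" and "open" are said of these compounds alone.

Among the measured compounds shown here, compound 2 `O=C(CN1C(=O)/C(=C/c2ccc(-c3ccc(Cl)cc3)o2)SC1=S)NCc1ccc(Br)cc1` holds the only number: in a functional assay on REH cells (Homo sapiens) for cytotoxicity, read by MTT assay, with a stated time of 72 h (on this read-out lower numbers stand for stronger inhibition and higher numbers for weaker inhibition), compound 2 gives 75000 nM. Compound 1 `N#Cc1cc(NC(=O)CN2C(=O)/C(=C/c3ccc(-c4ccc(Cl)cc4)o3)SC2=S)ccc1C(F)(F)F` reaches only a limit in this assay, > 250000 nM, which is the limit of > 250000 nM in this assay, at which 1 of the 2 values shown sits. For the measured compounds named here, the single measured step, an at least 3.3-fold lower number from compound 1 to compound 2 (0.52 log units; beyond the scatter), changes the substituent on the amide-type nitrogen. Compound 3 `CCCNC(=O)CN1C(=O)/C(=C/c2ccc(-c3ccc(Cl)cc3)o2)SC1=S` differs from compound 2 by ethyl in place of 4-bromophenyl on a saturated chain carbon bound to an amide-type nitrogen. Going by the values given here, no measured step bears directly on this change, so for compound 3 the expected step is a 2.0-fold higher number from compound 2 to compound 3 (0.30 log units; within the scatter), a weaker result within broad bounds. Compound 3 is estimated at 150000 nM, between 50000 nM and 250000 nM.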

Compound 3, half-maximal inhibitory concentration: 55000 nM
Estimate against measurement, compound 3: 2.7-fold (0.44 log units) above; the range from low to high includes it.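

In this assay, the ethyl in place of 4-bromophenyl on a saturated chain carbon bound to an amide-type nitrogen gives a 1.4-fold lower number from compound 2 to compound 3 (0.13 log units; within the scatter), so at this position the aromatic ring and bromine of compound 2 are not required to hold the result. A plain propyl on the amide-type nitrogen also separates from the 3-cyano-4-(trifluoromethyl)phenyl group, with an at least 4.5-fold lower number from compound 1 to compound 3 (0.65 log units; beyond the scatter). Compound 1 is held by a limit, so that step has no exact size: the limit of > 250000 nM in this assay, at which 1 of the 3 values shown sits.

As far as these compounds go, whether a longer chain, an amine or a carboxylic acid in place of propyl moves the number beyond the scatter stays open.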